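The source may report more compounds than this note shows. Statements on the series, on what has been measured and on what is new or still open speak of the compounds shown alone.

Of the compounds shown here, two have been tested so far in a functional assay on HepG2 cells (Homo sapiens) for inhibition, read by crystal violet staining, with a stated time of 48 h; a lower number here means a stronger inhibitor, a higher number a weaker inhibitor: compound 1 `COC(=O)CCn1c(=O)cc(Cl)[s+]1[O-]` and compound 2 `CCn1c(=O)c(C)c(Cl)[s+]1[O-]`. Compound 2 gives > 100000 nM, which is a limit of the assay and not a number. Compound 1, which also carries a methoxycarbonyl group, gives > 100000 nM, which is again a limit. Among the compounds with values here, the record so far is therefore (the limit of > 100000 nM in this assay, at which 2 of the 2 values shown sit), and no pair of measured compounds differs in just one place, so the size of a single change has not been seen directly.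

Compound 3 `COC(=O)CCn1c(=O)c(C)c(Cl)[s+]1[O-]` is built from compound 2 by one change: methoxycarbonyl in place of hydrogen on a saturated chain carbon, two bonds along the chain from an aromatic nitrogen. Methoxycarbonyl takes the place of hydrogen on a saturated chain carbon, two bonds along the chain from an aromatic nitrogen. No step beyond the usual scatter is expected in this assay, in either direction, because compound 1 with this group gives > 100000 nM. The expected result is a number no higher from compound 2 to compound 3 (the limit leaves the size open). For compound 3 the estimated value is 100000 nM, with an expected range of 40000 nM to 200000 nM.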

Compound 3, half-maximal inhibitory concentration: > 100000 nM
Compound 3 gave a limit, no number; the forecaster's own chance of this, stated with the estimate: 75%; the middle value sits exactly at the limit.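

Compound 3, like compound 1 and compound 2, gives only a limit and not a number, so neither the step from compound 2 to compound 3 nor the step from compound 1 to compound 3 can be read: the limit of > 100000 nM in this assay, at which 3 of the 3 values shown sit.

The compounds shown leave open how strongly any of them inhibits, and whether adding methoxycarbonyl or methyl changes that at all.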